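The source may hold more compounds than are shown below. What is called first, only, known or untested is meant among the compounds shown, and "the series" means these compounds.

Working notes on the series. Compound 1 `Nc1cc(N)c2nc(-c3ccccc3)c(NCc3ccc(Cl)c(Cl)c3)nc2c1` is the reference point here. Going by the values given here, in a functional assay on MCF7 cells (Homo sapiens) for inhibition, read by sulforhodamine B assay, with a stated time of 48 h (a lower number here means a stronger inhibitor of growth, a higher number a weaker inhibitor of growth), compound 1 gives 53700 nM, the only value in this set that is a number rather than a limit. Compound 2 `CCOC(=O)[C@H](CCC(=O)O)NC(=O)c1ccc(Sc2nc3cc(N)cc(N)c3nc2-c2ccccc2)cc1` reaches < 100000 nM in this assay, which is a limit of the assay and not a number. Compound 3 `Nc1cc(N)c2nc(-c3ccccc3)c(Oc3ccc(F)cc3)nc2c1` likewise sits at < 100000 nM in this assay, again a limit. Growth inhibition on the shared core is thus weak throughout, with the limit of < 100000 nM in this assay, at which 2 of the 3 values shown sit, marking where two of the three values sit, and compound 1 stands as the sole measured number, without a neighbour to rank it against.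

Compound 4 `COc1ccc(CNc2nc3cc(N)cc(N)c3nc2-c2ccccc2)cc1OC` is not yet measured. It differs from compound 1 by 3,4-dimethoxyphenyl in place of 3,4-dichlorophenyl on a saturated chain carbon bound to a nitrogen on an aromatic ring. Among the compounds with values here, no measured step between two compounds differing in one place exists in this set, so the size of the change can only be expected, not read off. The expected step is a 1.1-fold higher number from compound 1 to compound 4 (0.05 log units; within the scatter), that is, nothing beyond the usual scatter in this assay. Compound 4 is therefore estimated at 60000 nM in this assay, within a range from 20000 nM to 100000 nM.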

Compound 4, concentration for total growth inhibition: < 100000 nM
Compound 4 was reported as a limit; the forecaster's own chance of this, stated with the estimate: 35%; the middle value lies beyond the limit too.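

In this assay, going by these compounds alone, compound 4 gives < 100000 nM, which is a limit and not a number, so no step from compound 1 to compound 4 can be read. Whether 3,4-dimethoxyphenyl and 3,4-dichlorophenyl differ in growth inhibition on the shared core stays open, with most values resting at one limit: the limit of < 100000 nM in this assay, at which 3 of the 4 values shown sit.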